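The source may hold more compounds than are shown below. What is called first, only, known or untested is meant among the compounds shown, and "the series" means these compounds.

Working notes on the series. Three measured compounds share one core and differ in one place: compound 1 (`CCOC(=O)c1c(-c2cccc(OC)c2)[nH]c2cc(OC)c(F)cc2c1=O`), compound 2 (`CCOC(=O)c1c(-c2cccc(F)c2)[nH]c2cc(OC)c(F)cc2c1=O`) and compound 3 (`CCOC(=O)c1c(-c2cccc(Cl)c2)[nH]c2cc(OC)c(F)cc2c1=O`). In an ADME assay on Raji cells (Homo sapiens) for cytotoxicity, read by luminescence, with a stated time of 72 h (a lower number here means that less compound is needed, a higher number that more compound is needed for the effect), compound 1 gives > 21500 nM, which is a limit. In this assay compound 2 gives > 21500 nM, also a limit. Compound 3 gives > 21500 nM, again a limit and not a number. All three therefore stand at the same point: the limit of > 21500 nM in this assay, at which 3 of the 3 values shown sit.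

Compound 4 (`CCOC(=O)c1c(-c2cccc(Br)c2)[nH]c2cc(OC)c(F)cc2c1=O`) follows from compound 3 by one change: bromo in place of chloro on an aromatic carbon. This turns 3-chlorophenyl into 3-bromophenyl.

The nearest measured change is a step that the two limits leave unreadable from compound 2 to compound 3, with chloro in place of fluoro. The change a step that the two limits leave unreadable from compound 1 to compound 3 also bears on it. Neither has a readable size, so neither supports a shift in a particular direction in this assay. The expected change is a number no higher from compound 3 to compound 4 (the limit leaves the size open), with nothing expected beyond the scatter. For compound 4 the estimate is 21500 nM, with an expected range from 12000 nM to 40000 nM, and another limit is the likeliest report.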

Compound 4, half-maximal effective concentration: > 21500 nM
Compound 4: no number, only a limit; the forecaster's own chance of this, stated with the estimate: 85%; the middle value sits exactly at the limit.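

For the compounds shown here, compound 4 gives only a limit in this assay, so no step from compound 1, compound 2 or compound 3 to compound 4 can be read: the limit of > 21500 nM in this assay, at which 4 of the 4 values shown sit. The compounds shown leave open what number any of the four would give, and whether methoxy, fluoro, chloro and bromo differ at all.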